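A few compounds are considered here, and "the series" means these few. Any claim that something is new, unique, unknown or untested is made for them only; others in the source may bear on it.

Measured so far:
Compound 1 `O=C(CCCCC1CCSS1)Nc1ccccc1Cl` gives 5.11%
Compound 2 `CC(=O)SCCC(CCCCC(=O)Nc1ccccc1)SC(C)=O` gives 7.24%
Compound 3 `CC(=O)SCCC(CCCCC(=O)Nc1ccccc1Cl)SC(C)=O` gives 7.05%

In a functional assay on KB cells (Homo sapiens) for inhibition, read by MTT assay, with a stated time of 24 h, tested at 0.1 ug/mL (on this read-out higher numbers stand for more inhibition of growth at the one concentration tested and lower numbers for less inhibition of growth), compound 3 gives 7.05%, and the numbers for compound 3, compound 2 and compound 1 all lie within the scatter of one another, so they carry no order.

The next compound is compound 4 `CC(=O)SCCC(CCCCC(=O)Nc1ccc(Cl)cc1)SC(C)=O`, which differs from compound 3 as follows: 4-chlorophenyl in place of 2-chlorophenyl on an amide-type nitrogen. In words, this is 4-chlorophenyl in place of 2-chlorophenyl on an amide-type nitrogen.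

Among the measured compounds shown here, one measured step bears on this change: a number 0.2 percentage points lower from compound 2 to compound 3 (within the scatter) for chloro in place of hydrogen on an aromatic carbon. For the measured compounds named here, that evidence is only indirect, since no measured pair compares the two chlorophenyl groups. Nothing therefore points to a step beyond the scatter in this assay, and no direction is favoured.

The expected outcome is a number 0.5 percentage points higher from compound 3 to compound 4 (within the scatter), which stays within the scatter. The estimate for compound 4 is 7.5%, with an expected range from 2% to 16% in the same read-out.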

Compound 4, percent growth inhibition at one concentration: 11.4%
The estimate for compound 4 lay 3.9 percentage points below the measured number, within the range that was stated.
By their numbers in this assay, from the lowest: compounds 1, 3, 2 and 4 (each within the scatter of the next).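

In this assay, 4-chlorophenyl in place of 2-chlorophenyl on the amide-type nitrogen gives a number 4.4 percentage points higher from compound 3 to compound 4 (within the scatter), so the two chlorophenyl isomers are not separated on this read-out. Chloro in place of hydrogen on an aromatic carbon can now be read twice, as a number 0.2 percentage points lower from compound 2 to compound 3 (within the scatter) and as a number 4.2 percentage points higher from compound 2 to compound 4 (within the scatter), and neither reading sets a chlorophenyl compound apart from compound 2. No measurement shown bears on the reason for these numbers.

On these data alone, with a single concentration and every step within the scatter, it remains open whether the aromatic group on the amide-type nitrogen influences growth inhibition at all. A methoxy group, an amine or a carboxylic acid in place of the chloro could test this on the shared core.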